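The source may report more compounds than this note shows. Statements on the series, on what has been measured and on what is new or still open speak of the compounds shown alone.

Measured so far:
compound 1 `Cc1cccc(-c2noc(C3CN(S(=O)(=O)c4ccc(Cl)cc4)C3)n2)c1` — in an assay on HEK293 cells for positive allosteric modulation of metabotropic glutamate receptor 5 (Homo sapiens), read by FLIPR (on this read-out higher numbers stand for an effect only at larger amounts of compound and lower numbers for an effect already at smaller amounts), compound 1 reaches only the assay limit, > 10000 nM.
compound 2 `O=S(=O)(c1ccc(Cl)cc1)N1CC(c2nc(-c3cccc(Cl)c3)no2)C1` — in this assay compound 2 likewise stops at the limit, > 10000 nM.

Compound 2 thus stands at the limit, with no number of its own. The step that the two limits leave unreadable from compound 1 to compound 2 cannot be read because both ends sit at the limit of > 10000 nM in this assay, at which 2 of the 2 values shown sit. Compound 3 `Cc1ccc(S(=O)(=O)N2CC(c3nc(-c4cccc(Cl)c4)no3)C2)cc1` differs from compound 2 by methyl in place of chloro on an aromatic carbon. Within the data shown here, no measured step bears on this change. Since compound 2 gives only a limit, compound 3 is expected to stay at or near that limit. The step that the limit leaves unreadable from compound 2 to compound 3 is therefore estimated as none beyond the scatter. Compound 3 is estimated at 12000 nM, between 3000 nM and 50000 nM.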

Compound 3, half-maximal effective concentration: > 10000 nM
Compound 3: a limit, no number; the forecaster's own chance of this, stated with the estimate: 75%; the middle value lies beyond the limit too.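

No step can be read from compound 2 to compound 3, because both stop at the same assay limit: the limit of > 10000 nM in this assay, at which 3 of the 3 values shown sit.

The compounds shown leave open whether 4-chlorophenyl and 4-methylphenyl differ at all, and whether any compound in this series reaches a measurable value.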